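The source may report more compounds than this note shows. Statements on the series, on what has been measured and on what is new or still open speak of the compounds shown alone.

Measured in a functional assay on Ehrlich cells (Mus musculus) for cytotoxicity, tested at 100 ug/mL; a higher number here means a stronger effect of the compound at the concentration tested, a lower number a weaker effect:
compound 1 `COc1ccc(C2C(C#N)=C(N)N(c3cc(OC)c(OC)c(OC)c3)C3=C2C(=O)CC(C)(C)C3)cc1` gives 15%
compound 2 `COc1cc(N2C(N)=C(C#N)C(c3c(O)ccc4ccccc34)C3=C2CC(C)(C)CC3=O)cc(OC)c1OC` gives 90%
compound 3 `COc1cc(N2C(N)=C(C#N)C(c3ccc(C)o3)C3=C2CC(C)(C)CC3=O)cc(OC)c1OC` gives 50%

Compound 3 sits second highest of the three numbers in this assay. Its nearest neighbour is compound 1, with a number 35 percentage points higher from compound 1 to compound 3 (beyond the scatter); its furthest is compound 2, with a number 40 percentage points lower from compound 2 to compound 3 (beyond the scatter). The largest spread in the set is a number 75 percentage points higher from compound 1 to compound 2 (beyond the scatter).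

Compound 4 `COc1cc(N2C(N)=C(C#N)C(c3ccccc3)C3=C2CC(C)(C)CC3=O)cc(OC)c1OC` differs from compound 3 by phenyl in place of 5-methylfuran-2-yl on a saturated ring carbon. Within the data shown here, no measured step replaces this group by phenyl, so the bearing steps are only indirect: the step with a methoxy-bearing six-membered aromatic ring on that carbon, a number 35 percentage points higher from compound 1 to compound 3 (beyond the scatter), and the step from the hydroxynaphthalenyl, a number 40 percentage points lower from compound 2 to compound 3 (beyond the scatter). Phenyl stands structurally nearest to 4-methoxyphenyl of compound 1, which gives 15% in this assay. Compound 4 is therefore expected to fall below compound 3, with an estimated step of a number 25 percentage points lower from compound 3 to compound 4 (beyond the scatter). The estimate for compound 4 is 25%, in the range 5% to 55%.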

Compound 4, a percentage reported as activity, at one concentration (the size of the read-out at that concentration, not a potency): 10%
Compound 4: the middle estimate sits 15 percentage points above what was measured; low and high end bracket the measured number.
By their numbers in this assay, from the lowest: compounds 4 and 1 (each within the scatter of the next); then compound 3; then compound 2.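

In this assay, phenyl on the saturated ring carbon sits far under 5-methylfuran-2-yl (a number 40 percentage points lower from compound 3 to compound 4 (beyond the scatter)) and further still under 2-hydroxynaphthalen-1-yl (a number 80 percentage points lower from compound 2 to compound 4 (beyond the scatter)). Hydrogen in place of methoxy on the aromatic carbon gives no readable difference (a number 5 percentage points lower from compound 1 to compound 4 (within the scatter)), so the methoxy group does not separate compound 1 from compound 4, and the plain phenyl ring gives no gain of its own at this position. Nothing measured here accounts for these differences between the groups.

On these data alone, whether the high number of compound 2 goes with its hydroxy group or with its second fused ring stays open, and 2-hydroxyphenyl or unsubstituted naphthalen-1-yl on this carbon would separate the two. As far as these compounds go, for the furan, the part played by the methyl group is equally open, and unsubstituted furan-2-yl or thiophen-2-yl would test it.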